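The compounds below may be only part of what the source reports. "The series", "measured", "known", "first", "only" and "open" are said of these compounds alone.

Compound 1 `CC(c1cc(F)c2ncccc2c1)n1cnc2ncc(-c3cnn(C)c3)nc21` and compound 2 `Cc1c(C(C)n2cnc3ncc(-c4cnn(C)c4)nc32)ccc2ncccc12` carry the same side piece but differ in their cores; the difference between the two cores is not broken down here. In a functional assay on NCI-H1993 cells (Homo sapiens) for inhibition, read by CCK-8 assay, with a stated time of 72 h (on this read-out lower numbers stand for stronger inhibition and higher numbers for weaker inhibition), compound 1 gives > 10000 nM, which is a limit of the assay and not a number. In this assay, among the measured compounds shown here, compound 2 gives 206 nM, the only plain number among the three measured compounds. Compound 3 `CC(c1cc(F)c2ncccc2c1)n1cnc2ncc(-c3cn[nH]c3)nc21` arises from compound 1 by hydrogen in place of methyl on an aromatic nitrogen. In this assay compound 3 gives > 10000 nM, again a limit of the assay. The step that the two limits leave unreadable from compound 1 to compound 3 cannot be read because the limit of > 10000 nM in this assay, at which 2 of the 3 values shown sit, covers both ends of it. Compound 4 `Cc1c(C(C)n2cnc3ncc(-c4cn[nH]c4)nc32)ccc2ncccc12` arises from compound 2 by the same change, (hydrogen in place of methyl on an aromatic nitrogen). For the measured compounds named here, with the one measured instance of this change unreadable, the expectation for compound 4 rests on compound 2 alone, whose value in this assay is 206 nM. Compound 4 is expected to sit near 300 nM, somewhere between 80 nM and 2000 nM, which means an expected step of a 1.5-fold higher number from compound 2 to compound 4 (0.16 log units; within the scatter).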

Compound 4, half-maximal inhibitory concentration: 599 nM
The estimate for compound 4 lay 2.0-fold (0.30 log units) below the measured number, within the range that was stated.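

In this assay the change from 1-methyl-1H-pyrazol-4-yl to 1H-pyrazol-4-yl gives a 2.9-fold higher number from compound 2 to compound 4 (0.46 log units; beyond the scatter). Among the compounds shown here, this is the only readable instance of the change, so it gives a direction and a size on one core and does not show that either carries over to another core. The step from compound 1 to compound 3 cannot be read, because both of its ends sit at a limit of the assay and not at a number: the limit of > 10000 nM in this assay, at which 2 of the 4 values shown sit.

The compounds shown leave open whether the change would have a similar size on any further core. They also leave open how an ethyl group or a longer chain ending in an amine on that aromatic nitrogen would compare with methyl and hydrogen.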